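Adding a Methoxy Group: Expected Cytotoxicity of Compound 4

The compounds below may be only part of what the source reports. "The series", "measured", "known", "first", "only" and "open" are said of these compounds alone.

Three compounds have been measured in an ADME assay on MT4 cells (Homo sapiens) for cytotoxicity, read by MTT assay, with a stated time of 96 h; on this read-out higher numbers stand for lower toxicity in this test and lower numbers for higher toxicity in this test:

compound 1 `COc1ccc(-c2nc3cc(C(C)=O)ccc3[nH]2)c(OC)c1` gives 50000 nM
compound 2 `COc1ccc(-c2nc3cc(C(C)=O)ccc3[nH]2)c(OC)c1OC` gives only a limit of the assay, > 100000 nM
compound 3 `COc1ccc(-c2nc3cc(/C(C)=N/NC(N)=S)ccc3n2C2CCCCC2)cc1` gives 39000 nM

From compound 1 to compound 2 the change is methoxy in place of hydrogen on an aromatic carbon, and it gave an at least 2.0-fold higher number from compound 1 to compound 2 (0.30 log units; that floor lies within the scatter). This step rests on (the limit of > 100000 nM in this assay, at which 1 of the 3 values shown sits), so its true size is not known.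

Compound 4 `COc1ccc(-c2nc3cc(/C(C)=N/NC(N)=S)ccc3n2C2CCCCC2)c(OC)c1` is not yet measured. It differs from compound 3 by methoxy in place of hydrogen on an aromatic carbon. How the core of compound 3 differs from the core of compound 1 is not broken down here. The surroundings of the change also differ: in compound 2 the new methoxy sits ortho to two methoxy groups and meta to a large group, while in compound 4 it sits ortho to a large group and meta to a methoxy group, so this is the same kind of change rather than the same change.

Given the earlier step of an at least 2.0-fold higher number from compound 1 to compound 2 (0.30 log units; that floor lies within the scatter), compound 4 is expected to show a 1.7-fold higher number from compound 3 to compound 4 (0.22 log units; within the scatter) in this assay. The estimate for compound 4 is 65000 nM, with a range from 25000 nM to 150000 nM.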

Compound 4, half-maximal cytotoxic concentration: 17000 nM
Estimate against measurement, compound 4: 3.8-fold (0.58 log units) above; measured number below the stated range.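

Placed on the core of compound 3, methoxy in place of hydrogen gave a 2.3-fold lower number from compound 3 to compound 4 (0.36 log units; beyond the scatter) in this assay, whereas the earlier step went the opposite way, so the change did not carry over in direction from one core to the other: the same change on two cores in this assay, an at least 2.0-fold higher number (0.30 log units; that floor lies within the scatter) from compound 1 to compound 2 and a 2.3-fold lower number (0.36 log units; beyond the scatter) from compound 3 to compound 4, at least 4.5-fold (0.66 log units) apart, beyond the scatter of two such steps. Compound 2 gives > 100000 nM, which is a limit of the assay and not a number, so the earlier step has a known floor but no known full size. Among the compounds shown here, the comparison shows that the same kind of change can behave differently, but it does not show why: the cores differ, and the new methoxy in compound 4 sits ortho to a large group and meta to a methoxy group, unlike the one in compound 2.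

The compounds shown cannot separate the effect of the core from that of the surroundings of the new methoxy. Also open, as far as these compounds go, is what an ethoxy group or an amine would do in the same place on compound 3.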